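A few compounds are considered here, and "the series" means these few. Any claim that something is new, unique, unknown or untested is made for them only; others in the source may bear on it.

Three compounds built on a shared core were tested in a functional assay on A549 cells (Homo sapiens) for cytotoxicity, read by WST assay, with a stated time of 24 h; on this read-out lower numbers stand for stronger inhibition and higher numbers for weaker inhibition. Compound 1, `N#C/C(=C\c1c[nH]c2cc(F)ccc12)C(=O)c1c[nH]c2ccccc12`, gives 17000 nM in this assay. Compound 2, `COc1ccc2[nH]cc(C(=O)/C(C#N)=C/c3c[nH]c4cc(F)ccc34)c2c1`, carries one extra methoxy group compared with compound 1. In this assay compound 2 reaches only the limit of the assay, > 50000 nM, which is a limit and not a number. The change from compound 2 to compound 1 is hydrogen in place of methoxy on an aromatic carbon, and it produced an at least 2.9-fold lower number from compound 2 to compound 1 (0.46 log units; beyond the scatter). Compound 3, `COc1ccc2c(C(=O)/C(C#N)=C/c3cn(Cc4ccc(Cl)cc4)c4ccccc34)c[nH]c2c1`, also gives only a limit in this assay, > 50000 nM, again not a number. The measurements so far thus lean on (the limit of > 50000 nM in this assay, at which 2 of the 3 values shown sit). The difference between the core of compound 3 and the core of compound 2 is not broken down here.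

Compound 4, `N#C/C(=C\c1cn(Cc2ccc(Cl)cc2)c2ccccc12)C(=O)c1c[nH]c2ccccc12`, has not yet been measured in this assay. Among the compounds with values here, it differs from compound 3 by hydrogen in place of methoxy on an aromatic carbon, the same change at the same kind of place as the one that turned compound 2 into compound 1. Because that earlier change gave an at least 2.9-fold lower number from compound 2 to compound 1 (0.46 log units; beyond the scatter), a drop of comparable size is expected from compound 3 to compound 4, although the starting point for compound 3 is only a limit, so the size of the step is uncertain. The step from compound 3 to compound 4 is estimated at an at least 2.0-fold lower number from compound 3 to compound 4 (0.30 log units; that floor lies within the scatter). Compound 4 is therefore expected to give about 25000 nM, most likely between 8000 nM and 70000 nM.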

Compound 4, half-maximal inhibitory concentration: > 50000 nM
Compound 4: a limit, no number; the forecaster's own chance of this, stated with the estimate: 45%; at least 2.0-fold (0.30 log units) between middle value and limit.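

In this assay compound 4 gives > 50000 nM, which is a limit and not a number. Within the data shown here, compound 3 also sits at a limit, so no step from compound 3 to compound 4 can be read. It stays open whether replacing methoxy with hydrogen lowers the number on the core of compound 3 as it did from compound 2 to compound 1, because the results mostly rest on one value: the limit of > 50000 nM in this assay, at which 3 of the 4 values shown sit.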